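A Bromo Analogue Joins Three Compounds at the Assay Limit

The source may report more compounds than this note shows. Statements on the series, on what has been measured and on what is new or still open speak of the compounds shown alone.

Three compounds built on one shared core have been examined in a functional assay on NCI-H292 cells (Homo sapiens) for antiproliferative activity; a lower number here means a stronger inhibitor, a higher number a weaker inhibitor. Compound 1 `COc1ccc(N2C(=O)N/C(=C\c3ccc(O)cc3)C2=O)cc1` carries a methoxy group; in this assay compound 1 gives > 200000 nM, which is a limit of the assay and not a number. Compound 2 `O=C1N/C(=C\c2ccc(O)cc2)C(=O)N1c1cccc(I)c1` carries iodo; compound 2 gives > 200000 nM, again only a limit. Compound 3 `CCOC(=O)c1ccc(N2C(=O)N/C(=C\c3ccc(O)cc3)C2=O)cc1` carries ethoxycarbonyl; compound 3 gives > 200000 nM, once more a limit. The step from compound 1 to compound 3 is consequently a step that the two limits leave unreadable from compound 1 to compound 3. Within the data shown here, compound 3 thus stands exactly where every value so far stands, at the limit of > 200000 nM in this assay, at which 3 of the 3 values shown sit.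

Compound 4 `O=C1N/C(=C\c2ccc(O)cc2)C(=O)N1c1ccc(Br)cc1` is the next member of the set: bromo in place of ethoxycarbonyl on an aromatic carbon. Among the measured compounds shown here, no measured step shows how such an exchange moves the read-out, since the only step available cannot be read, and the remaining pair, compound 2 and compound 3, shows two limits and nothing more. The halogen-bearing compound 2 sits at the same limit as the others. The step from compound 3 to compound 4 is therefore expected to be a number no higher from compound 3 to compound 4 (the limit leaves the size open), with nothing beyond the scatter foreseen. Compound 4 is accordingly estimated at 200000 nM, with a range from 50000 nM to 1000000 nM.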

Compound 4, half-maximal inhibitory concentration: 69900 nM
Compound 4: the middle estimate sits 2.9-fold (0.46 log units) above what was measured; the range from low to high includes it.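

Among these compounds, at this place, on an aromatic carbon para to a large group, the earlier compounds gave only limits, whereas bromo gives the first readable result in this assay: bromo in place of ethoxycarbonyl gives an at least 2.8-fold lower number from compound 3 to compound 4 (0.45 log units; beyond the scatter), and bromo in place of methoxy gives an at least 2.8-fold lower number from compound 1 to compound 4 (0.45 log units; beyond the scatter). A halogen on the ring is not enough on its own, as the change to 4-bromophenyl in place of 3-iodophenyl on the amide-type nitrogen in a ring gives an at least 2.8-fold lower number from compound 2 to compound 4 (0.45 log units; beyond the scatter). Each of these steps starts from a limit, so its full size stays open, the step between the two limits of compound 1 and compound 3 still cannot be read, and only compound 4 has left the limit: the limit of > 200000 nM in this assay, at which 3 of the 4 values shown sit.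

The compounds shown leave open whether chloro or fluoro on this carbon would also give a readable number, and whether an amine or a carboxylic acid there would stay at the limit. They also leave open whether the bromine or its place matters more, as compound 2 and compound 4 differ in both the halogen and where it sits.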